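Trimming a Methoxy Group From the Shared Core

The source may hold more compounds than are shown below. What is called first, only, known or untested is meant among the compounds shown, and "the series" means these compounds.

Of the compounds shown here, two have been tested so far. Compound 1 `COc1cc(CS(=O)(=O)c2nc3ccccc3[nH]2)ccc1OCc1ncc(C)c(OC)c1C` gives 1820 nM in a functional assay on cells (Erythrocyte, Homo sapiens); on this read-out lower numbers stand for stronger inhibition and higher numbers for weaker inhibition. Compound 2 `COc1ccc2[nH]c(S(=O)(=O)Cc3ccc(OCc4nccc(OC)c4OC)c(OC)c3)nc2c1` gives 898 nM in this assay, the lowest of the two numbers; compound 1 sits a factor above it that exceeds the usual scatter, so compound 2 is the stronger inhibitor of the pair.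

Compound 3 `COc1cc(CS(=O)(=O)c2nc3ccccc3[nH]2)ccc1OCc1nccc(OC)c1OC` is the next question. It differs from compound 2 in one place: hydrogen in place of methoxy on an aromatic carbon. Cut one bond further out, the change reads 5-methoxy-1H-benzimidazol-2-yl to 1H-benzimidazol-2-yl. Going by the values given here, no pair with this exact change has yet been measured, so the direction of the step in this assay is open. A modest step is expected, if any, leaning toward a slightly higher number.

Compound 3 is estimated at 1300 nM, with a range of 500 nM to 3400 nM, an expected step of a 1.4-fold higher number from compound 2 to compound 3 (0.16 log units; within the scatter).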

Compound 3, half-maximal inhibitory concentration: 212 nM
Compound 3: middle estimate off by 6.1-fold (0.79 log units), on the high side; the whole stated range lies above it.
By their numbers in this assay, from the lowest: compound 3; then compound 2; then compound 1.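

At this aromatic carbon of the shared core, less proves better: hydrogen in place of methoxy gives a 4.2-fold lower number from compound 2 to compound 3 (0.63 log units; beyond the scatter) in this assay and so stronger inhibition, which shows that the methoxy group of 5-methoxy-1H-benzimidazol-2-yl is not needed here. The other end of the molecule also counts, since 3,4-dimethoxypyridin-2-yl in place of 4-methoxy-3,5-dimethylpyridin-2-yl gives an 8.6-fold lower number from compound 1 to compound 3 (0.93 log units; beyond the scatter) and leaves compound 3 as the strongest inhibitor of the three. Nothing available explains why either change acts this way.

On these data alone, only hydrogen and methoxy can be compared at this carbon, so it remains open how a chlorine atom, an amine or a carboxylic acid there would fare. As far as these compounds go, it is also open whether hydrogen would bring a similar gain alongside 4-methoxy-3,5-dimethylpyridin-2-yl.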